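The source may report more compounds than this note shows. Statements on the series, on what has been measured and on what is new or still open speak of the compounds shown alone.

Values in a functional assay on COLO 205 cells (Homo sapiens) for inhibition, read by sulforhodamine B assay, with a stated time of 48 h, tested at 50 uM (a higher number here means more inhibition of growth at the concentration tested, a lower number less inhibition of growth), for the three measured compounds:
- compound 1 `COc1cc(/C=C/C(=O)/C=C/c2cccc3ccccc23)ccc1OCc1cn(CCCOc2cc(=O)oc3ccccc23)nn1` gives 64%
- compound 2 `COc1cccc(/C=C/C(=O)/C=C/c2ccc(OCc3cn(CCOc4cc(=O)oc5ccccc45)nn3)c(OC)c2)c1` gives 69%
- compound 3 `COc1ccc(/C=C/C(=O)/C=C/c2ccc(OCc3cn(CCCCCOc4cc(=O)oc5ccccc45)nn3)c(OC)c2)cc1` gives 30%

Compound 1 (64%) lies within the scatter of compound 2 (69%), so these two cannot be ranked. The gap between compound 1 and compound 3 is beyond the scatter, with compound 1 the higher of the two.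

The compound still to be tested is compound 4 `COc1cccc(/C=C/C(=O)/C=C/c2ccc(OCc3cn(CCCOc4cc(=O)oc5ccccc45)nn3)c(OC)c2)c1` in the same assay, this assay. It differs from compound 1 in one place, with 3-methoxyphenyl in place of naphthalen-1-yl on a double-bonded chain carbon bound to a double-bonded chain carbon.

For the measured compounds named here, no two measured compounds differ in only one place, so the data give no direct measure of this swap. Without such a measure, no step beyond the scatter is expected, and the direction cannot be called with any confidence. The expected change, a number 2 percentage points lower from compound 1 to compound 4 (within the scatter), is therefore small. The range is kept wide, since compound 3 at 30% shows how low a value among these compounds can fall. For compound 4 the estimated value is 62%, expected to fall between 42% and 78%.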

Compound 4, percent growth inhibition at one concentration: 52%
The estimate for compound 4 lay 10 percentage points above the measured number, and the stated range covers the measured number.
By their numbers in this assay, from the lowest: compound 3; then compound 4; then compounds 1 and 2 (each within the scatter of the next).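

In this assay, the swap gives the first direct measure of a change at this position: 3-methoxyphenyl in place of naphthalen-1-yl on a double-bonded chain carbon bound to a double-bonded chain carbon gives a number 12 percentage points lower from compound 1 to compound 4 (beyond the scatter), a modest step but one that shows this end group affects growth inhibition. For the compounds shown here, the swap changes several things at once, replacing two six-membered aromatic rings with one, 10 heavy atoms with 8, and no hydrogen-bond acceptor with one, and the single step cannot show which of these differences matters. Nothing available here explains the lower number.

The compounds shown leave open whether the step comes from losing the second aromatic ring or from gaining the methoxy group, a question that an unsubstituted phenyl group at the same place could help to separate. They also leave open how very different groups at this place, such as a dimethylamino group or a carboxylic acid on the phenyl ring, would compare with 3-methoxyphenyl and naphthalen-1-yl.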